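A few compounds are considered here, and "the series" means these few. Any claim that something is new, unique, unknown or untested is made for them only; others in the source may bear on it.

Compound 1 `Cc1cc(C)c(Oc2cc(Nc3ccc(C#N)cc3)ncc2C(=O)NCc2cn(Cc3ccccc3F)nn2)c(C)c1`, compound 2 `Cc1cc(C)c(Oc2cc(Nc3ccc(C#N)cc3)ncc2C(=O)NCc2cn(Cc3cccc(Cl)c3)nn2)c(C)c1`, compound 3 `Cc1cc(C)c(Oc2cc(Nc3ccc(C#N)cc3)ncc2C(=O)NCc2cn(CCCO)nn2)c(C)c1`.

In an ADME assay on MT4 cells (Homo sapiens) for cytotoxicity, read by MTT assay, with a stated time of 5 days (on this read-out higher numbers stand for lower toxicity in this test and lower numbers for higher toxicity in this test), compound 1 gives > 222000 nM, which is a limit of the assay and not a number. In this assay compound 2 gives 187000 nM. In this assay compound 3 gives 25200 nM. Compound 1 thus stands at the limit (the limit of > 222000 nM in this assay, at which 1 of the 3 values shown sits), with no exact number.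

Compound 4 `Cc1cc(C)c(Oc2cc(Nc3ccc(C#N)cc3)ncc2C(=O)NCc2cn(Cc3ccccc3C)nn2)c(C)c1` differs from compound 1 in one place: methyl in place of fluoro on an aromatic carbon. The step that bears most on this change swaps one aryl group for another on the same chain carbon, an at least 1.1-fold lower number from compound 1 to compound 2 (0.07 log units; that floor lies within the scatter), and stayed within the scatter. The larger steps of an at least 8.8-fold lower number from compound 1 to compound 3 (0.94 log units; beyond the scatter) and a 7.4-fold lower number from compound 2 to compound 3 (0.87 log units; beyond the scatter) put a 2-hydroxyethyl in place of an aryl group and do not match this change. In this assay no step beyond the scatter is therefore expected, in either direction. Compound 4 is expected to give 222000 nM (range 100000 nM to 450000 nM), an estimated step of a number no higher from compound 1 to compound 4 (the limit leaves the size open).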

Compound 4, half-maximal cytotoxic concentration: >= 164000 nM
Compound 4: no number, only a limit (the forecaster's own chance of this, stated with the estimate: 60%); the middle value lies beyond the limit too.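

In this assay, compound 4 also gives a limit of the assay and not a number: the limit of >= 164000 nM in this assay, at which 1 of the 4 values shown sits.

A third aryl group, 2-methylphenyl, now sits well clear of the 2-hydroxyethyl group, with an at least 6.5-fold higher number from compound 3 to compound 4 (0.81 log units; beyond the scatter). The steps linking compound 4 with compound 1 and compound 2 cannot be read, so the swap of fluoro for methyl has no measurable size here.

From the compounds shown here alone, whether a methoxy group on the same aromatic carbon would shift the number stays open, as does the effect of a longer chain ending in an amine in place of the 2-hydroxyethyl group.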